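Dropping the methoxy arm for a plain indane ring

This account rests on a few compounds, and the source may have more. Where it says the series, first, only, none or still open, it means among the compounds named here.

Three compounds share one core. In an assay on CHO cells for agonist activity at 5-hydroxytryptamine receptor 1D (Homo sapiens), read by GTPgammaS binding (a lower number here means that less compound is needed, a higher number that more compound is needed for the effect), compound 1 `CN(Cc1cccs1)C1CCN(CCCc2c[nH]c3ccc(-n4cnnc4)cc23)CC1` gives 3.5 nM; compound 2 `O[C@@H]1Cc2ccccc2[C@H]1NC1CCN(CCCc2c[nH]c3ccc(-n4cnnc4)cc23)CC1` gives 13 nM; compound 3 `COC[C@H](NC1CCN(CCCc2c[nH]c3ccc(-n4cnnc4)cc23)CC1)c1ccccc1` gives 0.9 nM, the lowest number of the three. Compound 4 `c1ccc2c(c1)CCC2NC1CCN(CCCc2c[nH]c3ccc(-n4cnnc4)cc23)CC1` is not yet measured; its change from compound 3 is 2,3-dihydro-1H-inden-1-yl in place of 2-methoxy-1-phenylethyl on an amine nitrogen. The closest measured step is a 14-fold lower number from compound 2 to compound 3 (1.16 log units; beyond the scatter), where a hydroxylated indane group was replaced by the methoxy-phenylethyl group; compound 4 carries the indane group without that hydroxyl, so a partial return toward compound 2 is expected, with a 3.7-fold higher number from compound 1 to compound 2 (0.57 log units; beyond the scatter) as a second guide. Compound 4 is therefore expected to give 7 nM, between 2.5 nM and 25 nM, a step of a 7.8-fold higher number from compound 3 to compound 4 (0.89 log units; beyond the scatter) in this assay.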

Compound 4, half-maximal effective concentration: 25 nM
The estimate for compound 4 lay 3.6-fold (0.55 log units) below the measured number; low and high end bracket the measured number.
By their numbers in this assay, from the lowest: compound 3; then compound 1; then compounds 2 and 4 (each within the scatter of the next).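

In this assay the plain indane group does not stand in for the 2-methoxy-1-phenylethyl group on the amine nitrogen: the swap gives a 28-fold higher number from compound 3 to compound 4 (1.44 log units; beyond the scatter). The two indane compounds cannot be told apart (a 1.9-fold higher number from compound 2 to compound 4 (0.28 log units; within the scatter)), so the high number of compound 2 goes with the indane ring rather than its hydroxyl, and the thiophene amine also compares well (a 7.1-fold higher number from compound 1 to compound 4 (0.85 log units; beyond the scatter)). No measurement here explains these steps.

Whether compound 3 owes its low number to the methoxy or to the open chain stays unsettled. A 1-phenylethyl group, without the methoxy, on the same nitrogen would separate the two.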